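Losing the hydroxy group from compound 2

The compounds below may be only part of what the source reports. "The series", "measured", "known", "first", "only" and "open" are said of these compounds alone.

Compound 2 (`COc1nc2sc(C)cn2c1/C=C1/C(=O)Nc2ccc(O)cc21`) carries a hydroxy group on the shared core. Among the measured compounds shown here, in a functional assay on cells (Melanoma cell) for cytotoxicity against Melanoma cell line (Homo sapiens), read by sulforhodamine B assay, with a stated time of 48 h (a higher number here means a weaker inhibitor of growth, a lower number a stronger inhibitor of growth), compound 2 gives 4880 nM and lies within the scatter of the only other measured compound, compound 1 (`COc1ccc2c(c1)/C(=C\c1c(OC)nc3sc(C)cn13)C(=O)N2`), which gives 3460 nM in the same test.

The next compound, compound 3 (`COc1nc2sc(C)cn2c1/C=C1/C(=O)Nc2ccccc21`), has not yet been measured. The change is hydrogen in place of hydroxy on an aromatic carbon, so hydrogen stands in place of hydroxy on an aromatic carbon of a six-membered aromatic ring of carbon only. For the measured compounds named here, one measured step bears on this change: a 1.4-fold higher number from compound 1 to compound 2 (0.15 log units; within the scatter), where hydrogen replaced methyl on that same oxygen. That step stayed within the scatter, but it is only a partial guide, since compound 3 loses the oxygen itself. With so little evidence, no shift beyond the scatter is expected in this assay, and the uncertainty remains wide. The expected change is a 1.1-fold lower number from compound 2 to compound 3 (0.04 log units; within the scatter) on this estimate. Compound 3 is estimated to give 4500 nM, with a likely range from 1800 nM to 11000 nM.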

Compound 3, concentration for 50% growth inhibition: 16200 nM
The estimate for compound 3 lay 3.6-fold (0.56 log units) below the measured number, outside the stated range (above it).
By their numbers in this assay, from the lowest: compounds 1 and 2 (each within the scatter of the next); then compound 3.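

Compound 1 and compound 2 lie within the scatter of each other, so they showed only that hydroxy and methoxy can be exchanged at this position of the shared core without a clear shift in this assay. Compound 3 adds what they could not show: with no oxygen on this aromatic carbon, growth inhibition is weaker, whether hydrogen replaces hydroxy (a 3.3-fold higher number from compound 2 to compound 3 (0.52 log units; beyond the scatter)) or methoxy (a 4.7-fold higher number from compound 1 to compound 3 (0.67 log units; beyond the scatter)), and both steps lie beyond the scatter. No measurement given here explains why removing the oxygen has this effect.

With only hydroxy, methoxy and hydrogen shown at this position, it remains open whether an amine, a fluorine atom or a longer chain such as ethoxy would match compound 1 and compound 2 or fall closer to compound 3. Going by these compounds, it also remains open whether the same loss of growth inhibition would appear on a different shared core or in cells other than melanoma cells, since a single series in a single test cannot settle either question.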